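This account rests on a few compounds, and the source may have more. Where it says the series, first, only, none or still open, it means among the compounds named here.

Three compounds share one core and differ only in the group on an oxygen on an aromatic ring. In a functional assay on HeLa cells (Homo sapiens) for inhibition, read by CCK-8 assay, with a stated time of 48 h (a higher number here means a weaker inhibitor, a lower number a stronger inhibitor), compound 1 `O=C(NCCNS(=O)(=O)c1ccc(-c2ccccc2Oc2ccc(O)c(O)c2)s1)Nc1cc(Cl)cc(Cl)c1` gives only a limit, > 20000 nM. Compound 2 `O=C(NCCNS(=O)(=O)c1ccc(-c2ccccc2OCc2ccccc2)s1)Nc1cc(Cl)cc(Cl)c1` also gives only a limit in this assay, > 20000 nM. Compound 3 `O=C(NCCNS(=O)(=O)c1ccc(-c2ccccc2Oc2ccc([N+](=O)[O-])c([N+](=O)[O-])c2)s1)Nc1cc(Cl)cc(Cl)c1` likewise stops at a limit in this assay, > 20000 nM. Because (the limit of > 20000 nM in this assay, at which 3 of the 3 values shown sit), the steps a step that the two limits leave unreadable from compound 1 to compound 2, a step that the two limits leave unreadable from compound 1 to compound 3 and a step that the two limits leave unreadable from compound 2 to compound 3 cannot be sized. Compound 4 `COc1ccc(NC(=O)NCCNS(=O)(=O)c2ccc(-c3ccccc3OCc3ccccc3)s2)cc1` alters a different part of the molecule: 4-methoxyphenyl in place of 3,5-dichlorophenyl on an amide-type nitrogen. For the measured compounds named here, no measured step touches that position, so the earlier steps give neither size nor direction for it. Compound 4 is therefore expected to remain near the limit, at 20000 nM with a range from 5000 nM to 60000 nM. The estimated step is a number no higher from compound 2 to compound 4 (the limit leaves the size open).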

Compound 4, half-maximal inhibitory concentration: > 50000 nM
Compound 4: no number, only a limit (the forecaster's own chance of this, stated with the estimate: 75%); middle value at least 2.5-fold (0.39 log units) away from the limit.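

Compound 2 gives only a limit, > 20000 nM. Compound 4 also gives only a limit, > 50000 nM. The step between compound 2 and compound 4 cannot be read. The compounds shown leave open what 4-methoxyphenyl in place of 3,5-dichlorophenyl does to inhibition in this assay.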